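This account rests on a few compounds, and the source may have more. Where it says the series, first, only, none or still open, it means among the compounds named here.

Working notes on the series. Compound 1 `COc1cc(OC)cc(-c2nc3cc(C(F)(F)F)ccc3[nH]2)c1` is the reference point. In an ADME assay on MDBK cells (Bos taurus) for cytotoxicity, read by MTT assay, with a stated time of 96 h (on this read-out higher numbers stand for lower toxicity in this test and lower numbers for higher toxicity in this test), compound 1 gives > 100000 nM, which is a limit of the assay rather than a number (the limit of > 100000 nM in this assay, at which 1 of the 2 values shown sits). Compound 2 `COc1cc(-c2nc3cc(C(F)(F)F)ccc3[nH]2)cc(OC)c1OC` carries one more methoxy group; in this assay compound 2 gives 18000 nM. Among the compounds with values here, the only measured step, an at least 5.5-fold lower number from compound 1 to compound 2 (0.74 log units; beyond the scatter), runs toward higher toxicity. Compound 3 `COc1cccc(-c2nc3cc(C(F)(F)F)ccc3[nH]2)c1` differs from compound 1 by hydrogen in place of methoxy on an aromatic carbon, the opposite kind of change. The measured step therefore gives no ground for a lower number, and compound 1 already stands at the limit. For compound 3 the expected step is a number no higher from compound 1 to compound 3 (the limit leaves the size open). Compound 3 is estimated at 100000 nM, between 40000 nM and 300000 nM, most likely again reported only as a limit.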

Compound 3, half-maximal cytotoxic concentration: 28000 nM
Compound 3: the middle estimate sits 3.6-fold (0.55 log units) above what was measured; the measured number lies below the stated range.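

In this assay, hydrogen in place of methoxy on the aromatic carbon gives an at least 3.5-fold lower number from compound 1 to compound 3 (0.55 log units; beyond the scatter), toward higher toxicity in this test. Taking a methoxy group away from compound 1 thus moves the number the same way as adding one, which an at least 5.5-fold lower number from compound 1 to compound 2 (0.74 log units; beyond the scatter) already showed. The value of compound 1 is a limit, and the true size of both steps stays open: the limit of > 100000 nM in this assay, at which 1 of the 3 values shown sits.

The compounds shown leave open how a hydroxyl, an amine or a fluorine on this carbon would read. As far as these compounds go, whether any of these would return the number to the limit of compound 1 also remains open.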